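The compounds below may be only part of what the source reports. "The series", "measured", "known", "first", "only" and "open" are said of these compounds alone.

Measured so far in an assay on HEK293 cells for inhibition of N-acylethanolamine-hydrolyzing acid amidase (Rattus norvegicus), read by LC-MS, with a stated time of 30 min; a higher number here means a weaker inhibitor, a lower number a stronger inhibitor:
Compound 1, `O=C(CCCCCCc1ccccc1)N1CCCC1`: 12900 nM
Compound 2, `O=C(CCCCCCc1ccccc1F)N1CCCC1`: 13700 nM

Among the measured compounds shown here, compound 2 holds the higher of the two numbers in this assay, but its only neighbour, compound 1, sits within the scatter of it: the single measured step, a 1.1-fold higher number from compound 1 to compound 2 (0.03 log units; within the scatter), is within the usual repeat variation. Compound 3, `O=C(CCCCCCc1ccccc1Cl)N1CCCC1`, carries the change (chloro in place of fluoro on an aromatic carbon). For the measured compounds named here, the one step that bears on it, a 1.1-fold higher number from compound 1 to compound 2 (0.03 log units; within the scatter), showed no movement beyond scatter, and no exchange of one halogen for another has been measured. The writer therefore expects no step beyond the scatter in this assay for compound 3. Compound 3 is estimated at 13000 nM, within 5000 nM to 35000 nM, an expected step of a 1.1-fold lower number from compound 2 to compound 3 (0.02 log units; within the scatter).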

Compound 3, half-maximal inhibitory concentration: > 100000 nM
Compound 3: a limit, no number; the forecaster's own chance of this, stated with the estimate: 10%; middle value at least 7.6-fold (0.88 log units) away from the limit.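

In this assay, compound 3 gives a limit of the assay and not a number: the limit of > 100000 nM in this assay, at which 1 of the 3 values shown sits.

The position on an aromatic carbon, ortho to a large group, is therefore not indifferent to what it carries, which compound 2 alone did not show. Chloro in place of fluoro gives an at least 7.2-fold higher number from compound 2 to compound 3 (0.86 log units; beyond the scatter), and chloro in place of hydrogen gives an at least 7.7-fold higher number from compound 1 to compound 3 (0.88 log units; beyond the scatter).

The compounds shown leave open whether bromo or methyl in that place would stay with fluoro and hydrogen or go with chloro. They also leave open whether a longer chain would change the effect of chloro.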